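Acyl group exchange on the shared core: compound 3

The source may report more compounds than this note shows. Statements on the series, on what has been measured and on what is new or still open speak of the compounds shown alone.

Measured so far:
compound 1, `CCCC(=O)N1CCC(NS(=O)(=O)c2ccc(NC(=O)CC3CCCC3)c3ccccc23)CC1`, 145 nM
compound 2, `CCCCc1ccc(C(=O)Nc2ccc(S(=O)(=O)NC3CCN(C(=O)CCC)CC3)c3ccccc23)cc1`, 15.3 nM

In an in vitro functional assay on CHO/Galpha16 cells for antagonist activity at C-C chemokine receptor type 8 (Homo sapiens), read by FLIPR (on this read-out higher numbers stand for weaker inhibition and lower numbers for stronger inhibition), compound 2 gives 15.3 nM, the lowest of the two numbers; the nearest is compound 1 with 145 nM. Among the compounds with values here, the single measured step at the carbonyl carbon is a 9.5-fold lower number from compound 1 to compound 2 (0.98 log units; beyond the scatter). Compound 3, `CCCC(=O)N1CCC(NS(=O)(=O)c2ccc(NC(=O)c3nccn3C)c3ccccc23)CC1`, is not yet measured; it differs from compound 2 by 1-methyl-1H-imidazol-2-yl in place of 4-butylphenyl on a carbonyl carbon. Within the data shown here, the step from compound 1 to compound 2 shows that exchanging the group on this carbonyl carbon shifts this assay beyond the scatter, but no measured pair holds a five-membered aromatic ring with 2 hetero atoms at this place, so the direction rests on judgement only. The wide change in group, from 10 heavy atoms to 6, suggests a move back toward higher numbers. Compound 3 is expected to give 150 nM, in the range 30 nM to 800 nM. This estimate corresponds to a 9.8-fold higher number from compound 2 to compound 3 (0.99 log units; beyond the scatter).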

Compound 3, half-maximal inhibitory concentration: 20.4 nM
Beside the measured number, compound 3's estimate is 7.4-fold (0.87 log units) above it; measured number outside the range, below it.
By their numbers in this assay, from the lowest: compounds 2 and 3 (each within the scatter of the next); then compound 1.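

In this assay, replacing 4-butylphenyl on the carbonyl carbon with 1-methyl-1H-imidazol-2-yl gives a 1.3-fold higher number from compound 2 to compound 3 (0.12 log units; within the scatter) and so shows that this place accepts a group with fewer heavy atoms, with nitrogen in the ring and with hydrogen-bond acceptors, without a step beyond the scatter. Against cyclopentylmethyl, the same exchange gives a 7.1-fold lower number from compound 1 to compound 3 (0.85 log units; beyond the scatter) and so sets both aromatic groups apart from the one non-aromatic group in this set, with no listed compound going against that split. No evidence on the cause of these steps is at hand.

Whether the aromatic ring alone accounts for the split remains open, as the set holds neither an unsubstituted phenyl nor a saturated ring attached directly to the carbonyl carbon. Also open, as far as these compounds go, is how a pyridine ring, or an imidazole carrying an amine or a carboxylic acid, would read at this place.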